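A few compounds are considered here, and "the series" means these few. Any claim that something is new, unique, unknown or untested is made for them only; others in the source may bear on it.

Measured compounds:
compound 1 `COc1ccc(C(=O)/C=C/c2cc(-c3cc(OC)c(OC)c(OC)c3)n[nH]2)cc1OC` — 101%
compound 2 `COc1ccc(C(=O)/C=C/c2cc(-c3cc(OC)c(OC)c(OC)c3)n[nH]2)cc1` — 94%

In a functional assay on MDA-MB-231 cells (Homo sapiens) for cytotoxicity, read by sulforhodamine B assay, with a stated time of 48 h, tested at 0.1 uM (on this read-out higher numbers stand for a weaker effect at the one concentration tested and lower numbers for a stronger effect), compound 1 gives 101% and compound 2 gives 94%. For the measured compounds named here, the one step seen so far, a number 7 percentage points lower from compound 1 to compound 2 (within the scatter), does not separate the two; compound 2 therefore stands at the same level as compound 1, and neither shows an appreciable effect at the one concentration tested.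

Compound 3 `COc1cc(-c2cc(/C=C/C(=O)c3ccc(F)c(F)c3)[nH]n2)cc(OC)c1OC` is not yet measured. It differs from compound 2 by 3,4-difluorophenyl in place of 4-methoxyphenyl on a carbonyl carbon. Going by the values given here, the only measured step changes the same ring of the molecule, but by a different exchange, so it bears on the new step only loosely; what it shows is that altering substituents on that ring left the read-out within the scatter. No step beyond the scatter is therefore expected for compound 3 in this assay, a number 1 percentage points higher from compound 2 to compound 3 (within the scatter), and the read-out of compound 3 is estimated at 95%, within 80% to 106%.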

Compound 3, a percentage reported as activity, at one concentration (the size of the read-out at that concentration, not a potency): 96%
Compound 3: the middle estimate sits 1 percentage points below what was measured; low and high end bracket the measured number.
By their numbers in this assay, from the lowest: compounds 2, 3 and 1 (each within the scatter of the next).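

In this assay the exchange of 4-methoxyphenyl for 3,4-difluorophenyl on the carbonyl carbon gives a number 2 percentage points higher from compound 2 to compound 3 (within the scatter), and the exchange of 3,4-dimethoxyphenyl for the same group gives a number 5 percentage points lower from compound 1 to compound 3 (within the scatter). The earlier step removed a single methoxy, whereas these steps leave no methoxy on that ring and put fluorine there, and the three compounds still cannot be told apart at the one concentration tested. Nothing at hand bears on why this ring exchange leaves the read-out within the scatter.

On these data alone, whether an amine or a carboxylic acid on this ring would move the read-out remains open. Also open, as far as these compounds go, is whether these compounds separate at a higher concentration, as a single-concentration read-out gives no potency.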